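Fluoro for trifluoromethyl on the shared core

The source may report more compounds than this note shows. Statements on the series, on what has been measured and on what is new or still open speak of the compounds shown alone.

The shared core of compound 1 `CN1CCN(c2nc3cc([N+](=O)[O-])ccc3o2)CC1` carries a nitro group and gives 6.1 in a functional assay on ileum (strain Hartley) for agonist activity at 5-hydroxytryptamine receptor 3A (Cavia porcellus); a higher number here means a more potent compound, by a factor of ten per unit of this negative logarithm, a lower number a less potent compound. Compound 2 `Cc1cccc2nc(N3CCN(C)CC3)oc12` gives 5.48 in this assay. Compound 3 `CN1CCN(c2nc3cc(C(F)(F)F)ccc3o2)CC1` carries trifluoromethyl in place of the nitro group. For compound 3 the read-out is a limit of the assay, not a number: < 4. The step from compound 1 to compound 3 was a number at least 2.10 log units lower from compound 1 to compound 3 (beyond the scatter), and the limit of < 4 in this assay, at which 1 of the 3 values shown sits, is what sets the position of compound 3.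

Compound 4 `CN1CCN(c2nc3cc(F)ccc3o2)CC1` is not yet measured. The change is fluoro in place of trifluoromethyl on an aromatic carbon. Among the compounds with values here, the only measured step that bears on it, a number at least 2.10 log units lower from compound 1 to compound 3 (beyond the scatter), concerns a different substituent entering the same place and ends at a limit, so the size of the present step cannot be read from it. The expectation is a step of a number at least 0.80 log units higher from compound 3 to compound 4 (beyond the scatter) in this assay, with wide uncertainty and a real chance that compound 4 again reaches only a limit. Compound 4 is estimated at 4.8, between 4 and 5.8.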

Compound 4, negative logarithm of the half-maximal effective concentration: 5.57
The estimate for compound 4 lay 0.77 log units below the measured number; the range from low to high includes it.
By their numbers in this assay, from the lowest: compounds 2 and 4 (each within the scatter of the next); then compound 1. At a limit, below all of these: compound 3.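

Replacing nitro on this aromatic carbon costs much less with fluoro than with trifluoromethyl: a number 0.53 log units lower from compound 1 to compound 4 (beyond the scatter) in this assay stands against a number at least 2.10 log units lower from compound 1 to compound 3 (beyond the scatter) for the other replacement. Exchanging trifluoromethyl for fluoro on the same carbon gives a number at least 1.57 log units higher from compound 3 to compound 4 (beyond the scatter), so the loss of potency depends on the group that enters and does not follow from the removal of nitro alone. That last step gives a bound and not a size, since compound 3 stands at a limit: the limit of < 4 in this assay, at which 1 of the 4 values shown sits.

As far as these compounds go, how far compound 3 lies beyond that limit remains open. From the compounds shown here alone, three groups on this carbon give no trend, and it is also open where an amine, a methoxy group or a chlorine atom would fall in this assay relative to fluoro and nitro.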